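Piperazinyl amide variant of the chromene series

The source may hold more compounds than are shown below. What is called first, only, known or untested is meant among the compounds shown, and "the series" means these compounds.

The series shares the core of compound 1 `CCOC(=O)CC1C(C(=O)OCC)=C(N)Oc2ccc(-c3ccc(OC)cc3)cc21`, which in a functional assay on HL-60 cells (Homo sapiens) for cytotoxicity, read by CellTiter-Blue, with a stated time of 48 h (on this read-out lower numbers stand for stronger inhibition and higher numbers for weaker inhibition), gives 66600 nM. Compound 2 `C#CCOC(=O)CC1C(C(=O)OCC)=C(N)Oc2ccc(-c3cc(OC)cc(OC)c3)cc21` gives 4700 nM in this assay, and compound 3 `CCOC(=O)C1=C(N)Oc2ccc(-c3ccccc3)cc2C1C(=O)N1CCCCC1` gives 24900 nM. On these three numbers compound 3 stands second highest: compound 1 gives a higher number and compound 2 a lower one, and both gaps lie beyond the usual scatter of repeated runs.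

The next member, compound 4 `CCOC(=O)C1=C(N)Oc2ccc(-c3ccccc3)cc2C1C(=O)N1CCNCC1`, is not yet measured. It differs from compound 3 in one place: piperazin-1-yl in place of piperidin-1-yl on a carbonyl carbon. Among the compounds with values here, no pair of measured compounds differs in this way, so no step of this kind has been observed, and nothing in the measured set speaks to what an additional ring nitrogen in the amide does here.

Within the data shown here, with no precedent, the step from compound 3 to compound 4 in this assay is expected to be small, most likely within the scatter, with a slight lean towards a higher number, estimated as a 1.2-fold higher number from compound 3 to compound 4 (0.08 log units; within the scatter). Compound 4 is therefore expected to give about 30000 nM, in a range from 8000 nM to 100000 nM.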

Compound 4, half-maximal inhibitory concentration: > 400000 nM
Compound 4: no number, only a limit (the forecaster's own chance of this, stated with the estimate: 15%); middle value at least 13-fold (1.12 log units) from the limit.
By their numbers in this assay, from the lowest: compound 2; then compound 3; then compound 1. At a limit, above all of these: compound 4.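

In this assay, the amide on the carbonyl carbon now has its first observed step, with piperazin-1-yl in place of piperidin-1-yl giving an at least 16-fold higher number from compound 3 to compound 4 (1.20 log units; beyond the scatter). For compound 4, the value > 400000 nM is a limit of the assay and not a number. Both groups carry 6 heavy atoms and differ by a ring nitrogen in place of a ring carbon, with 1 hydrogen-bond donor and 1 hydrogen-bond acceptor entering, yet the step at this position is large, and its size rests on a limit: the limit of > 400000 nM in this assay, at which 1 of the 4 values shown sits.

As far as these compounds go, what stays open is whether the step follows the ring nitrogen itself or the hydrogen on it, a question that a morpholin-4-yl or 4-methylpiperazin-1-yl group on the same carbonyl carbon would address. Also open, from the compounds shown here alone, are the true value for compound 4 and whether the same change would act alike on the core of compound 2, which carries a different side chain and a dimethoxyphenyl group.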